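Notes on the carbonyl substituent of compound 2

A few compounds are considered here, and "the series" means these few. Any claim that something is new, unique, unknown or untested is made for them only; others in the source may bear on it.

Measured so far:
compound 1 `CC[C@@H](C)[C@H](NC(=O)c1ccc(C(CC)(CC)c2ccc(OCC(=O)C(C)(C)C)c(C)c2)n1CC)C(=O)OC` — 590 nM
compound 2 `CCN(CC)CCNC(=O)c1ccc(C(CC)(CC)c2ccc(OCC(O)C(C)(C)C)c(C)c2)n1CC` — 110 nM
compound 3 `CCn1c(C(=O)OC(C)CCO)ccc1C(CC)(CC)c1ccc(OCC(=O)C(C)(C)C)c(C)c1` — 380 nM

Values come from an assay on HL-60 cells for agonist activity at vitamin D3 receptor (Homo sapiens), read by microscopy, with a stated time of 96 h; on this read-out lower numbers stand for an effect already at smaller amounts and higher numbers for an effect only at larger amounts of compound. Compound 2 has the lowest number of the three; its gaps to compound 3 and to compound 1 both lie beyond the scatter, so it is the most potent of the measured set.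

The next compound, compound 4 `CCn1c(C(=O)N(C)CC(=O)O)ccc1C(CC)(CC)c1ccc(OCC(O)C(C)(C)C)c(C)c1`, keeps the rest of compound 2 and changes only the substituent on the carbonyl carbon: (carboxymethyl)(methyl)amino in place of (2-(diethylamino)ethyl)amino on a carbonyl carbon.

For the measured compounds named here, one measured step bears on this position. Going a 1.6-fold lower number from compound 1 to compound 3 (0.19 log units; within the scatter), the group on the carbonyl carbon was exchanged without a change beyond the scatter, which suggests that this assay tolerates variation there. Going by the values given here, that step, however, swapped two ester-type groups, while the present change introduces a carboxymethyl group; no measured compound carries a free acid, so the expectation is loosely held.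

On this basis compound 4 is expected to stay in the neighbourhood of compound 2, with a modest rise in the number considered more likely than a fall; the estimated step is a 2.3-fold higher number from compound 2 to compound 4 (0.36 log units; beyond the scatter). For compound 4 the estimate in this assay is 250 nM, with a range from 80 nM to 800 nM.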

Compound 4, half-maximal effective concentration: 740 nM
Estimate against measurement, compound 4: 3.0-fold (0.47 log units) below; the measured number falls inside the stated range.
By their numbers in this assay, from the lowest: compound 2; then compounds 3, 1 and 4 (each within the scatter of the next).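

In this assay, for the compounds shown here, the carbonyl carbon of this series proves sensitive to the group it carries: (carboxymethyl)(methyl)amino in place of (2-(diethylamino)ethyl)amino gives a 6.7-fold higher number from compound 2 to compound 4 (0.83 log units; beyond the scatter) and so lies beyond the scatter, whereas the only earlier step at this carbon, a 1.6-fold lower number from compound 1 to compound 3 (0.19 log units; within the scatter) stayed within it. The tolerance suggested by that earlier step therefore does not extend to every group here, even though the computed counts of hydrogen-bond donors and acceptors are the same for the two groups and neither carries a net charge. The data offer no measured explanation for the size of this step.

This single exchange removes the diethylamino end, adds a carboxylic acid and places a methyl on the amide nitrogen all at once, so the compounds shown do not assign the step to any one of these changes. Open too, from the compounds shown here alone, is how a (carboxymethyl)amino group without that methyl, a methyl ester in place of the carboxylic acid, or a longer chain ending in a carboxylic acid would read in this assay on the core of compound 2 .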